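Removing the amino linker from a coumarin-type inhibitor

The source may hold more compounds than are shown below. What is called first, only, known or untested is meant among the compounds shown, and "the series" means these compounds.

Measured compounds:
- compound 1, `C[C@H](Nc1cc(=O)oc2cc(OCc3ccccc3)ccc12)C(N)=O`: 100000 nM
- compound 2, `NC(=O)Cc1cc(=O)oc2cc(OCc3cccc(F)c3)ccc12`: 70000 nM
- compound 3, `NC(=O)Cc1cc(=O)oc2cc(OCc3cccc(O)c3)ccc12`: 4270 nM

In an assay (strain Wistar) for inhibition of Amine oxidase [flavin-containing] A (Rattus norvegicus) (a higher number here means a weaker inhibitor, a lower number a stronger inhibitor), compound 1 gives 100000 nM, the highest number of the three, so it is the weakest inhibitor here. Compound 2 sits within the scatter of compound 1, whereas compound 3 lies well below both. Going by the values given here, the only step between two compounds that differ in one place, a 16-fold lower number from compound 2 to compound 3 (1.21 log units; beyond the scatter), concerns the group at the end of the benzyl ether, not the side chain at the other end of the shared core.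

Compound 4, `CC(C(N)=O)c1cc(=O)oc2cc(OCc3ccccc3)ccc12`, differs from compound 1 by 1-carbamoylethyl in place of (1-carbamoylethyl)amino on an aromatic carbon. Among the compounds with values here, no measured pair shows this change directly. Compounds 2 and 3 carry their amide side chain without such a linking nitrogen and the one with the closest benzyl ether, compound 2, gives 70000 nM. The expected step is therefore small and within the scatter, a 1.7-fold lower number from compound 1 to compound 4 (0.22 log units; within the scatter). Compound 4 is estimated at 60000 nM in this assay, with a range from 15000 nM to 200000 nM.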

Compound 4, half-maximal inhibitory concentration: 6260 nM
For compound 4 the middle estimate is 9.6-fold (0.98 log units) above the measured one; measured number below the stated range.
By their numbers in this assay, from the lowest: compounds 3 and 4 (each within the scatter of the next); then compounds 2 and 1 (each within the scatter of the next).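

Going by these compounds alone, until now the only readable step lay on the benzyl ether; this one shows that the position opposite the ring oxygen also counts in this assay. Taking out the nitrogen that joins the side chain to the aromatic carbon gives a 16-fold lower number from compound 1 to compound 4 (1.20 log units; beyond the scatter), a large step for so small an edit. Nothing available explains why this change has so large an effect.

The step also mixes two changes: the group that leaves has a defined stereocentre and the group that enters has none, so the share of the nitrogen cannot be separated from that of the stereochemistry. On these data alone, whether an oxygen linker or a longer chain at this position, or a carboxylic acid in place of the amide, would keep the lower number remains open.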